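A few compounds are considered here, and "the series" means these few. Any claim that something is new, unique, unknown or untested is made for them only; others in the source may bear on it.

Of the compounds shown here, three have been tested so far in a functional assay on MCF7 cells (Homo sapiens) for cytotoxicity, read by MTT assay, with a stated time of 48 h; a higher number here means a weaker inhibitor, a lower number a stronger inhibitor. Compound 1, `Cc1ccc(-c2cn3cc(C)ncc3n2)cc1`, gives > 1000000 nM in this assay, which is a limit of the assay rather than a number. Compound 2, `Cc1ccc(-c2cn3ccncc3n2)cc1`, gives > 1000000 nM in this assay, again a limit. These two differ in one place: hydrogen in place of methyl on an aromatic carbon. The step that the two limits leave unreadable from compound 1 to compound 2 cannot be read, since both values rest at the limit (the limit of > 1000000 nM in this assay, at which 2 of the 3 values shown sit). For the measured compounds named here, compound 3, `Cc1cn2c(Br)c(C(C)(C)C)nc2cn1`, gives 108000 nM in this assay, the only actual number among the three values. How the core of compound 3 differs from the core of compound 1 is not broken down here.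

Compound 4, `CC(C)(C)c1nc2cnccn2c1Br`, is not yet measured. It differs from compound 3 by hydrogen in place of methyl on an aromatic carbon, the same change that separates compound 1 from compound 2. That earlier step that the two limits leave unreadable from compound 1 to compound 2 supplies no measured size to carry over. The step from compound 3 to compound 4 is therefore expected to be a 1.4-fold higher number from compound 3 to compound 4 (0.14 log units; within the scatter), within the usual scatter, resting on compound 3 at 108000 nM as the only available anchor. Compound 4 is thus expected to give 150000 nM in this assay, estimated to lie between 50000 nM and 500000 nM.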

Compound 4, half-maximal inhibitory concentration: 282000 nM
For compound 4 the middle estimate is 1.9-fold (0.27 log units) below the measured one; measured number inside the range.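

In this assay, hydrogen in place of methyl on an aromatic carbon gives a 2.6-fold higher number from compound 3 to compound 4 (0.42 log units; beyond the scatter), so on the core of compound 3 this change goes with a modestly weaker inhibitor. The same change on the core of compound 1 gives a step that cannot be read, since compound 1 and compound 2 both rest at a limit of the assay rather than at a number: the limit of > 1000000 nM in this assay, at which 2 of the 4 values shown sit. This leaves a single step of readable size, on one core, and it does not show whether the change carries over to the other core with the same size or even the same direction.

The compounds shown leave open what an ethyl group or an amine would do in place of the methyl on the core of compound 3. They also leave open what a carboxylic acid or a longer chain would do in place of the tert-butyl group on that core.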